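The source may hold more compounds than are shown below. What is called first, only, known or untested is meant among the compounds shown, and "the series" means these compounds.

Measured so far:
Compound 1, `Cc1c(C(C)C)c(=O)on1C(=O)N1CCCCC1`: 2 nM
Compound 2, `Cc1c(C(C)C)c(=O)on1C(=O)N(C)CCC#N`: > 1000 nM

In an assay (strain Wistar) for inhibition of Hormone-sensitive lipase (Rattus norvegicus), read by spectrophotometry (a higher number here means a weaker inhibitor, a lower number a stronger inhibitor), compound 1 gives 2 nM. For compound 2 the result is > 1000 nM, which is a limit of the assay and not a number. These two compounds differ in one place, and that single change gave an at least 500-fold higher number from compound 1 to compound 2 (2.69 log units; beyond the scatter). Compound 2 thus sits at the limit of > 1000 nM in this assay, at which 1 of the 2 values shown sits, and is the weaker of the two inhibitors shown.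

Compound 3, `Cc1c(C(C)C)c(=O)on1C(=O)N1CCCC1`, differs from compound 2 by pyrrolidin-1-yl in place of (2-cyanoethyl)(methyl)amino on a carbonyl carbon. Going by the values given here, this brings back a ring amine on the carbonyl carbon, as compound 1 carries, so the only measured step that bears on it is an at least 500-fold higher number from compound 1 to compound 2 (2.69 log units; beyond the scatter), read in reverse. A large step back towards a lower number is therefore expected, an at least 200-fold lower number from compound 2 to compound 3 (2.30 log units; beyond the scatter). Compound 3 is estimated at 5 nM, with a range from 1 nM to 60 nM.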

Compound 3, half-maximal inhibitory concentration: 15 nM
For compound 3 the middle estimate is 3.0-fold (0.48 log units) below the measured one; measured number inside the range.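

Putting a ring amine back on the carbonyl carbon recovers much of the strength missing from compound 2, with an at least 66-fold lower number from compound 2 to compound 3 (1.82 log units; beyond the scatter). Compound 2 stands at a limit of the assay and not at a number: the limit of > 1000 nM in this assay, at which 1 of the 3 values shown sits. Ring size also counts among these compounds, since the smaller ring does not fully match the piperidin-1-yl group, with a 7.5-fold higher number from compound 1 to compound 3 (0.88 log units; beyond the scatter), so having a ring on this carbonyl carbon does not alone set the strength.

Compound 2 both lacks the ring and carries a nitrile, and the compounds shown do not separate these two differences. From the compounds shown here alone, how a plain diethylamino group or a larger, seven-membered azepan-1-yl ring would read on this carbonyl carbon also remains open.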